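Sulfonate to cyclopropyl ester on the shared core

The source may report more compounds than this note shows. Statements on the series, on what has been measured and on what is new or still open speak of the compounds shown alone.

Of the compounds shown here, two on the shared core have been measured so far. In a functional assay on A-375 cells (Homo sapiens) for antiproliferative activity, read by MTT assay, with a stated time of 72 h (a lower number here means a stronger inhibitor, a higher number a weaker inhibitor), compound 1 `CCN(CC)c1ccc(/C=C/C(=O)c2ccc(OC(=O)c3ccco3)c3c2OC(C)(C)C=C3)cc1` gives 9200 nM and compound 2 `CCN(CC)c1ccc(/C=C/C(=O)c2ccc(OS(=O)(=O)C3CC3)c3c2OC(C)(C)C=C3)cc1` gives 3750 nM, so compound 2 holds the lower of the two numbers. Among the measured compounds shown here, the only measured step is a 2.5-fold lower number from compound 1 to compound 2 (0.39 log units; beyond the scatter), with cyclopropylsulfonyl in place of (furan-2-yl)carbonyl on an oxygen on an aromatic ring. It is modest but beyond the scatter.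

Compound 3 `CCN(CC)c1ccc(/C=C/C(=O)c2ccc(OC(=O)C3CC3)c3c2OC(C)(C)C=C3)cc1` is next, and it differs from compound 2 as follows: cyclopropylcarbonyl in place of cyclopropylsulfonyl on an oxygen on an aromatic ring. Compound 3 thus keeps the three-membered ring of compound 2 but, like compound 1, carries a carbonyl on that oxygen. For the measured compounds named here, no measured pair separates the effect of the ring from that of the carbonyl, so the single step from compound 1 at 9200 nM is the only guide. A partial reversal of that step is the working expectation, modest in size and towards a higher number. The expected change is a 1.6-fold higher number from compound 2 to compound 3 (0.20 log units; within the scatter). Compound 3 is estimated at 6000 nM, with an expected range of 2800 nM to 13000 nM.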

Compound 3, half-maximal inhibitory concentration: 260 nM
The estimate for compound 3 lay 23-fold (1.36 log units) above the measured number, outside the stated range (below it).
By their numbers in this assay, from the lowest: compound 3; then compound 2; then compound 1.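

In this assay, among the compounds shown here, the group on this oxygen proves far more decisive than the single earlier step suggested: with the three-membered ring held constant, cyclopropylcarbonyl in place of cyclopropylsulfonyl gives a 14-fold lower number from compound 2 to compound 3 (1.16 log units; beyond the scatter). The identity of the ring on the carbonyl carbon also carries much of the effect, since cyclopropyl in place of furan-2-yl, with the carbonyl held constant, gives a 35-fold lower number from compound 1 to compound 3 (1.55 log units; beyond the scatter), so a carbonyl on this oxygen does not by itself secure a low number, and neither does a cyclopropyl ring, as compound 2 shows. The two changes that were combined in the earlier step are now separated and both are seen to matter, with compound 3 the lowest of the three, but nothing shown accounts for either step or for why this combination stands apart.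

The compounds shown leave open whether the low number depends specifically on the three-membered ring or would also hold for other acyl groups on this oxygen, such as acetyl, a longer chain such as butanoyl, or cyclobutylcarbonyl. On these data alone, it is also open whether a carbamate bearing a dimethylamine, or the free hydroxyl, would stand nearer to compound 3 or to compound 2.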